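From ethoxymethyl to carboxy on a shared core

The compounds below may be only part of what the source reports. "The series", "measured", "known", "first", "only" and "open" are said of these compounds alone.

Values measured so far in a functional assay on KBVIN cells (Homo sapiens) for cytotoxicity, read by sulforhodamine B assay, with a stated time of 3 days (a lower number here means that less compound is needed, a higher number that more compound is needed for the effect), are:
- compound 1 `CCOCc1c(C)coc1-c1ccc2c(c1OC)CCCC2(C)C` at 16.5 uM
- compound 2 `Cc1coc(-c2ccc3c(c2O)CCCC3)c1C(=O)O` at 29.4 uM
- compound 3 `Cc1coc(-c2ccc3c(c2O)CCCC3(C)C)c1C(=O)O` at 4.7 uM

Compound 1 stands with compound 2 at the high end of these numbers, the two lying within the scatter of each other, while compound 3 has a lower number beyond the scatter. Compound 4 `COc1c(-c2occ(C)c2C(=O)O)ccc2c1CCCC2(C)C` remains unmeasured. It differs from compound 1 thus: carboxy in place of ethoxymethyl on an aromatic carbon. Among the measured compounds shown here, no measured step isolates this change. Compound 2 (29.4 uM) and compound 3 (4.7 uM) both carry carboxy, yet only compound 2 stays within the scatter of compound 1, so no clear direction is expected. The estimated step of a 1.3-fold lower number from compound 1 to compound 4 (0.10 log units; within the scatter) is expected to stay within the scatter in this assay measurements. Compound 4 is expected to give 13 uM with an estimated range from 5 uM to 32 uM in this test.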

Compound 4, concentration for half-maximal effect: 47.8 uM
Beside the measured number, compound 4's estimate is 3.7-fold (0.57 log units) below it, outside the stated range (above it).
By their numbers in this assay, from the lowest: compound 3; then compounds 1, 2 and 4 (each within the scatter of the next, the first and the last beyond it).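

In this assay, among the compounds shown here, the step of a 2.9-fold higher number from compound 1 to compound 4 (0.46 log units; beyond the scatter) shows for the first time, on an otherwise unchanged core, that carboxy in place of ethoxymethyl on an aromatic carbon raises the number beyond the scatter. With carboxy kept, the step of a 10-fold higher number from compound 3 to compound 4 (1.01 log units; beyond the scatter) shows that methyl in place of hydrogen on an oxygen on an aromatic ring also raises it, and this step is the large one. Nothing given here accounts for either step.

The compounds shown leave open how an amide or an amine would read at the carboxy position. They also leave open whether ethoxymethyl responds in the same way when that oxygen carries hydrogen rather than methyl.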